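A few compounds are considered here, and "the series" means these few. Any claim that something is new, unique, unknown or untested is made for them only; others in the source may bear on it.

In a functional assay on HeLa cells (Homo sapiens) for cytotoxicity, read by MTT assay, with a stated time of 24 h (a lower number here means a stronger inhibitor, a higher number a weaker inhibitor), compound 1 `CCCCCCCCCCn1cc(-c2nc3ccccc3cc2C)nn1` gives 28.2 ug/mL. Compound 2 `CCCCCCCCCCn1cc(-c2nc3ccccc3cc2CCCC)nn1` carries a butyl chain in place of the methyl of compound 1, and in this assay compound 2 gives > 100 ug/mL, which is a limit of the assay and not a number. The measured step between them, an at least 3.5-fold higher number from compound 1 to compound 2 (0.54 log units; beyond the scatter), therefore shows that lengthening the chain weakened the inhibition by at least this much, with the true size unknown since the number for compound 2 is capped by the limit of > 100 ug/mL in this assay, at which 1 of the 2 values shown sits.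

Compound 3 `CCCCCCCCCCn1cc(-c2nc3ccccc3cc2CC)nn1` has an ethyl chain, so it sits between compounds 1 and 2 in chain length. The change from compound 2 is hydrogen in place of ethyl on a saturated chain carbon, two bonds along the chain from an aromatic carbon. For the measured compounds named here, the only measured step that bears on it is the one from compound 1 to compound 2, which ran in the opposite direction and was at least modest. Shortening the chain partway back is expected to lower the number, giving an estimated step of an at least 1.8-fold lower number from compound 2 to compound 3 (0.25 log units; that floor lies within the scatter) from compound 2 to compound 3. The expected value for compound 3 is 55 ug/mL, within a range of 22 ug/mL to 130 ug/mL.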

Compound 3, half-maximal inhibitory concentration: > 100 ug/mL
Compound 3 gave a limit, no number (the forecaster's own chance of this, stated with the estimate: 30%); middle value at least 1.8-fold (0.25 log units) away from the limit.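

In this assay compound 3 gives > 100 ug/mL, which is a limit of the assay and not a number. Putting ethyl in place of the methyl of the shared core already gives an at least 3.5-fold higher number from compound 1 to compound 3 (0.54 log units; beyond the scatter), so the weakening seen with the butyl chain of compound 2 does not need a chain that long, and the ethyl chain is enough to show it beyond the scatter. The step from compound 2 to compound 3 cannot be read, since both values are limits, so nothing can be said on whether butyl is worse than ethyl: the limit of > 100 ug/mL in this assay, at which 2 of the 3 values shown sit.

The compounds shown leave open how weak compound 2 and compound 3 really are, and whether the number changes gradually or abruptly as the chain grows past methyl. They also leave open what hydrogen in place of the methyl of compound 1 would give, and whether a chain carrying an amine or a carboxylic acid at this place would bring the number back down into the range that can be read.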